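The source may report more compounds than this note shows. Statements on the series, on what has been measured and on what is new or still open speak of the compounds shown alone.

Working notes on the series. In a functional assay on KB cells (Homo sapiens) for cytotoxicity (a lower number here means that less compound is needed, a higher number that more compound is needed for the effect), compound 1 (`COC1=C(C)C(=O)/C(=C(O)/C=C/c2ccc(Br)cc2)C(=O)C1(C)C`) gives 1.9 ug/mL, compound 2 (`COC1=C(C)C(=O)/C(=C(O)/C=C/c2ccc(OC)cc2)C(=O)C1(C)C`) gives 2.9 ug/mL and compound 3 (`COC1=C(C)C(=O)/C(=C(O)/C=C/c2ccc(C)cc2)C(=O)C1(C)C`) gives 1.9 ug/mL. Compound 3 stands level with compound 1 at the digits shown and within the scatter of compound 2.

Compound 4 (`CCc1ccc(/C=C/C(O)=C2/C(=O)C(C)=C(OC)C(C)(C)C2=O)cc1`) differs from compound 3 by one change: methyl in place of hydrogen on a saturated chain carbon bound to an aromatic carbon. In words, this is methyl in place of hydrogen on a saturated chain carbon bound to an aromatic carbon, or 4-methylphenyl to 4-ethylphenyl.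

Within the data shown here, no measured step makes this same change. The closest evidence is the exchange of groups on an aromatic carbon: a 1.5-fold higher number from compound 1 to compound 2 (0.18 log units; within the scatter), no change at the digits printed from compound 1 to compound 3 (within the scatter) and a 1.5-fold lower number from compound 2 to compound 3 (0.18 log units; within the scatter). All three stay within the scatter, so no step beyond the scatter is expected in this assay. The expected step is a 1.1-fold higher number from compound 3 to compound 4 (0.04 log units; within the scatter). Compound 4 is estimated at 2.1 ug/mL, with an expected range of 1.1 ug/mL to 4 ug/mL.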

Compound 4, concentration for half-maximal effect: 1.9 ug/mL
For compound 4 the middle estimate is 1.1-fold (0.04 log units) above the measured one; measured number inside the range.
By their numbers in this assay, from the lowest: compounds 1, 3, 4 and 2 (each within the scatter of the next).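

The 4-methylphenyl to 4-ethylphenyl change, made on a saturated chain carbon bound to an aromatic carbon and not on the aromatic carbon itself, gives no change at the digits printed from compound 3 to compound 4 (within the scatter) in this assay and so extends the group at this position by a methyl without moving the number beyond the scatter. Ethyl also compares with the two other groups on the aromatic carbon, giving no change at the digits printed from compound 1 to compound 4 (within the scatter) and a 1.5-fold lower number from compound 2 to compound 4 (0.18 log units; within the scatter) so that bromo, methoxy, methyl and ethyl all remain within the scatter of one another in this assay at this position. No measurement on these compounds offers an explanation for this result.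

The compounds shown leave open whether a longer chain such as butyl, an amine or a carboxylic acid in this place would also stay within the scatter. They also leave open how changes elsewhere on the shared core would read in this assay with these groups in place.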